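Adding a second methoxy group to a cyclised core

The source may report more compounds than this note shows. Statements on the series, on what has been measured and on what is new or still open speak of the compounds shown alone.

Two pairs of compounds are compared here. Compound 1 `COc1ccc(/C=N/c2c(C#N)ncn2-c2ccc(F)cc2)cc1` carries an open imine linkage and a nitrile on its core. In a functional assay on MCF7 cells (Homo sapiens) for antiproliferative activity, read by MTT assay, with a stated time of 48 h (a higher number here means a weaker inhibitor, a lower number a stronger inhibitor), compound 1 gives 9330 nM. Compound 2 `COc1ccc(/C=N/c2c(C#N)ncn2-c2ccc(F)cc2)cc1OC` differs from it only at one spot on the outer ring: methoxy in place of hydrogen on an aromatic carbon. In this assay compound 2 gives 14700 nM. The step of a 1.6-fold higher number from compound 1 to compound 2 (0.20 log units; within the scatter) shows how little this addition altered the read-out in that pair.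

Compound 3 `COc1ccc(C2N=C(C(N)=O)c3ncn(-c4ccc(F)cc4)c3N2)cc1` has a different core, in which the chain has closed into a ring and the nitrile has become a primary amide. The difference between the two cores is not broken down here. In this assay compound 3 gives 3990 nM, the lowest of the three numbers and beyond the scatter from both compound 1 and compound 2.

Compound 4 `COc1ccc(C2N=C(C(N)=O)c3ncn(-c4ccc(F)cc4)c3N2)cc1OC` stands to compound 3 exactly as compound 2 stands to compound 1: methoxy in place of hydrogen on an aromatic carbon. The place of the change is the same in both pairs, so this is the same change made on the cyclised core. A similarly small step is expected here, namely a 1.6-fold higher number from compound 3 to compound 4 (0.21 log units; within the scatter), because the matching earlier step was a 1.6-fold higher number from compound 1 to compound 2 (0.20 log units; within the scatter). On that basis compound 4 is expected to give about 6400 nM in this assay, most likely between 3000 nM and 14000 nM.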

Compound 4, half-maximal inhibitory concentration: 5710 nM
The estimate for compound 4 lay 1.1-fold (0.05 log units) above the measured number, within the range that was stated.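

On the cyclised core, methoxy in place of hydrogen on an aromatic carbon gives a 1.4-fold higher number from compound 3 to compound 4 (0.16 log units; within the scatter) in this assay, so compound 3 and compound 4 cannot be told apart in this read-out, just as the matching pair on the open core could not. Among the compounds shown here, in this series, then, the small size of the step carried over from one core to the other, and the two steps cannot be told apart either: the same change on two cores in this assay, a 1.6-fold higher number (0.20 log units; within the scatter) from compound 1 to compound 2 and a 1.4-fold higher number (0.16 log units; within the scatter) from compound 3 to compound 4, 1.1-fold (0.04 log units) apart, within the scatter of two such steps This shows only that the added methoxy group left no effect larger than the scatter on either of these two cores in this one assay; it does not show that the group truly weakens the compounds, that the two similar steps share a cause, or that the same would hold on any further core.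

The compounds shown leave open whether another group on the same aromatic carbon, such as a hydroxyl group, a chlorine atom, an amine or a longer chain like ethoxy, would give a larger step. They also leave open whether such a step would then keep its size on both cores, which is the real test of how well a change carries across this series.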